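Amide nitrogen variation across a shared core

The source may hold more compounds than are shown below. What is called first, only, known or untested is meant among the compounds shown, and "the series" means these compounds.

Measured compounds:
compound 1 `CCNC(=O)CC1CCc2cc(OC)c(OC)cc21` — 20.4%
compound 2 `COc1cc2c(cc1OC)C(CC(=O)NC(C)C)CC2` — 37%
compound 3 `COc1cc2c(cc1OC)C(CC(=O)NCc1ccccc1)CC2` — 30.6%

All three were read in a functional assay on the whole organism (strain Wistar) for inhibition, with Rattus norvegicus as the target, read by paw edema, with stated times of 60 min and 6 h, at a dose of 100 mg/kg by the oral route; on this read-out higher numbers stand for more inhibition at the one dose given (going by the name of the read-out) and lower numbers for less inhibition. Compound 3 stands second highest of the three numbers: its gap to compound 2 is within the scatter, while the step of a number 10.2 percentage points higher from compound 1 to compound 3 (beyond the scatter) lies beyond it. Compound 4 `COc1cc2c(cc1OC)C(CC(=O)N1CCNCC1)CC2` differs from compound 3 by piperazin-1-yl in place of benzylamino on a carbonyl carbon. The measured steps all concern the group on the amide nitrogen: a number 16.6 percentage points higher from compound 1 to compound 2 (beyond the scatter), a number 10.2 percentage points higher from compound 1 to compound 3 (beyond the scatter), a number 6.4 percentage points lower from compound 2 to compound 3 (within the scatter). None of them removes the amide hydrogen or closes a ring onto that nitrogen, so they bear only loosely on this change; the two beyond the scatter were modest rises, the third lay within the scatter. For compound 4 no step beyond the scatter is expected, a number 0.6 percentage points lower from compound 3 to compound 4 (within the scatter). Compound 4 is estimated at 30%, within 15% to 45%.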

Compound 4, a percentage reported as inhibition, in the whole organism at one dose (the size of the read-out at that dose, not a potency): 33.3%
Beside the measured number, compound 4's estimate is 3.3 percentage points below it; the range from low to high includes it.
By their numbers in this assay, from the lowest: compound 1; then compounds 3, 4 and 2 (each within the scatter of the next).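

In this assay, piperazin-1-yl on the carbonyl carbon shows that a ring closed onto the amide nitrogen, with the amide hydrogen gone, still reads alongside the open amides: a number 2.7 percentage points higher from compound 3 to compound 4 (within the scatter) and a number 3.7 percentage points lower from compound 2 to compound 4 (within the scatter). Only ethylamino stands apart, with a number 12.9 percentage points higher from compound 1 to compound 4 (beyond the scatter). Nothing available accounts for this result. Open, as far as these compounds go, is whether the second ring nitrogen of piperazin-1-yl matters at all. Morpholin-4-yl or piperidin-1-yl on the same carbonyl carbon would separate that nitrogen from the ring itself.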